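Shortening the thioether chain on a chloromethyl ketone

The source may hold more compounds than are shown below. What is called first, only, known or untested is meant among the compounds shown, and "the series" means these compounds.

Measured compounds:
compound 1, `CC(=O)N[C@@H](CSC/C=C(\C)CCC=C(C)C)C(=O)C=[N+]=[N-]`, > 100000 nM
compound 2, `CC(=O)N[C@@H](CSCC=C(C)C)C(=O)C=[N+]=[N-]`, > 100000 nM
compound 3, `CC(=O)N[C@@H](CSC/C=C(\C)CCC=C(C)C)C(=O)CCl`, > 100000 nM

All three compounds share an acetylated amino acid core with a sulfur-linked side chain and a reactive ketone. In a functional assay on MOLT-3 cells (Homo sapiens) (on this read-out lower numbers stand for stronger inhibition and higher numbers for weaker inhibition), compound 3 gives > 100000 nM, which is a limit of the assay and not a number. Compound 3 therefore stands at the same place as the other two, since (the limit of > 100000 nM in this assay, at which 3 of the 3 values shown sit).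

The unmeasured compound 4, `CC(=O)N[C@@H](CSCC=C(C)C)C(=O)CCl`, differs from compound 3 by hydrogen in place of 3-methylbut-2-en-1-yl on a saturated chain carbon bound to a double-bonded chain carbon. The same shortening of the side chain was made once before, on the diazoketone, and gave a step that the two limits leave unreadable from compound 1 to compound 2. The exchange of the reactive group itself gave a step that the two limits leave unreadable from compound 1 to compound 3. Neither step can be read, so no size or direction can be expected in this assay beyond what the limit allows.

Compound 4 is thus estimated to remain at the limit, with an expected step that the limit leaves unreadable from compound 3 to compound 4 from compound 3. The expected value for compound 4 is 150000 nM, within a range from 60000 nM to 400000 nM.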

Compound 4, half-maximal inhibitory concentration: 7900 nM
The estimate for compound 4 lay 19-fold (1.28 log units) above the measured number; the measured number lies below the stated range.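

In this assay, putting hydrogen in place of 3-methylbut-2-en-1-yl on the chloromethyl ketone gives an at least 12-fold lower number from compound 3 to compound 4 (1.10 log units; beyond the scatter), so the length of the sulfur-linked chain matters at this position once the reactive group is a chloromethyl ketone. Going by these compounds alone, on the shorter chain, exchanging the diazoketone for the chloromethyl ketone gives an at least 12-fold lower number from compound 2 to compound 4 (1.10 log units; beyond the scatter), so the reactive group matters too, which the earlier steps could not show, as none of them can be read. The two changes count only in combination among these compounds, since compound 2 carries the shorter chain alone, compound 3 carries the chloromethyl ketone alone, and neither leaves the limit: the limit of > 100000 nM in this assay, at which 3 of the 4 values shown sit.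

Within the data shown here, compound 4 is the only compound here with a real number, so the full size of both steps stays unknown, and one compound cannot show whether the shorter chain is the best length or merely a better one than the longer chain. Also open, on these data alone, is how a plain methyl or ethyl group on the sulfur would behave, and whether a bromomethyl ketone could take the place of the chloromethyl ketone.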